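Carbonyl substituent change on the ketone-bearing compound 1

The compounds below may be only part of what the source reports. "The series", "measured", "known", "first", "only" and "open" are said of these compounds alone.

The series shares one core, seen in compound 1 `C#CCNC(=O)c1ccc(C(CC)(CC)c2ccc(OCC(=O)C(C)(C)C)c(C)c2)n1CC`, which in an assay on HL-60 cells for agonist activity at vitamin D3 receptor (Homo sapiens), read by microscopy, with a stated time of 96 h (on this read-out lower numbers stand for an effect already at smaller amounts and higher numbers for an effect only at larger amounts of compound), gives 2200 nM. Compound 2 `C#CCNC(=O)c1ccc(C(CC)(CC)c2ccc(OCC(O)C(C)(C)C)c(C)c2)n1CC` carries 1-hydroxy-2,2-dimethylpropyl where compound 1 has (tert-butyl)carbonyl; in this assay compound 2 gives 240 nM, and the step is a 9.2-fold lower number from compound 1 to compound 2 (0.96 log units; beyond the scatter). Compound 3 `C#CCCOC(=O)c1ccc(C(CC)(CC)c2ccc(OCC(O)C(C)(C)C)c(C)c2)n1CC` keeps that hydroxyl but carries (but-3-yn-1-yl)oxy on the carbonyl carbon and gives 1030 nM; the step is a 4.3-fold higher number from compound 2 to compound 3 (0.63 log units; beyond the scatter). Compound 1 thus shows the highest number of the three, with compound 3 closest to it and compound 2 furthest from it.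

Compound 4 `CCn1c(C(=O)OC(C)CCO)ccc1C(CC)(CC)c1ccc(OCC(=O)C(C)(C)C)c(C)c1` keeps the (tert-butyl)carbonyl of compound 1 and changes only the carbonyl substituent: a group of 6 heavy atoms (4 carbon, 2 oxygen; no ring) in place of a group of 4 heavy atoms (3 carbon, 1 nitrogen; no ring), on a carbonyl carbon. The entering group, like the (but-3-yn-1-yl)oxy of compound 3, is joined to the carbonyl carbon through oxygen rather than nitrogen, so of the measured steps only a 4.3-fold higher number from compound 2 to compound 3 (0.63 log units; beyond the scatter) bears on it, and that step moved the number upward. The ketone side of compound 4 matches compound 1, so a 9.2-fold lower number from compound 1 to compound 2 (0.96 log units; beyond the scatter) does not apply here. The expected step is a 2.7-fold higher number from compound 1 to compound 4 (0.44 log units; beyond the scatter), upward and beyond the scatter. Compound 4 is therefore estimated at 6000 nM in this assay, within 2000 nM to 18000 nM.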

Compound 4, half-maximal effective concentration: 380 nM
Beside the measured number, compound 4's estimate is 16-fold (1.20 log units) above it; the measured number lies below the stated range.
By their numbers in this assay, from the lowest: compounds 2 and 4 (each within the scatter of the next); then compound 3; then compound 1.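

Within the data shown here, on the ketone-bearing core, the carbonyl carbon tolerates more than the one upward step suggested: in this assay, the group of 6 heavy atoms replacing propargylamino gives a 5.8-fold lower number from compound 1 to compound 4 (0.76 log units; beyond the scatter). Among these compounds, a link through oxygen therefore does not raise the number on its own, since the only earlier change at this carbonyl carbon, to (but-3-yn-1-yl)oxy, went the other way with a 4.3-fold higher number from compound 2 to compound 3 (0.63 log units; beyond the scatter), and the triple bond present in propargylamino is absent from the group entering compound 4. Nothing measured here accounts for the opposite directions of these two steps.

Going by these compounds, these two steps differ both in the entering group and in the ketone or hydroxyl on the other side of the molecule, so it remains open whether the group in compound 4 would lower the number on the hydroxyl-bearing partner, compound 2, as well. Also open, on these data alone, is what at this carbonyl carbon drives the drop in compound 4: the oxygen link or the chain itself, a question that an amide carrying the same chain through nitrogen, a simple methyl ester or a carboxylic acid would help to settle.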